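Swapping Fluoro for Methyl on the Weakest Measured Compound

A few compounds are considered here, and "the series" means these few. Any claim that something is new, unique, unknown or untested is made for them only; others in the source may bear on it.

Measured so far:
Compound 1 `O=C1O/C(=C\Cn2ccc(NC(=O)c3ccccc3)nc2=O)C(OCc2ccccc2)=C1OCc1ccccc1`, which in a functional assay on MCF7 cells (Homo sapiens) for inhibition, read by MTT assay, with a stated time of 72 h (a higher number here means a weaker inhibitor, a lower number a stronger inhibitor), gives 2030 nM.
Compound 2 `NC1(CCn2cc(F)c(=O)[nH]c2=O)OC(=O)C(OCc2ccccc2)=C1OCc1ccccc1`, which in this assay gives 20900 nM.
Compound 3 `O=C1O/C(=C\Cn2c(=O)[nH]c(=O)[nH]c2=O)C(OCc2ccccc2)=C1OCc1ccccc1`, which in this assay gives 17800 nM.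

Compound 2 has the highest number of the three. Its gap to compound 3 lies within the scatter, so those two cannot be ordered; its gap to compound 1 lies beyond the scatter, so compound 1 is the stronger inhibitor of that pair.

Compound 4 `Cc1cn(CCC2(N)OC(=O)C(OCc3ccccc3)=C2OCc2ccccc2)c(=O)[nH]c1=O` is not yet measured. It differs from compound 2 in one place: methyl in place of fluoro on an aromatic carbon. Within the data shown here, no measured pair shows this exact change, so there is no step to lean on. A single atom exchanged for another of the same size, with no change in ring, donors, acceptors or charge, is expected to move the number little. For compound 4 the expected step of a 1.2-fold higher number from compound 2 to compound 4 (0.09 log units; within the scatter) is therefore small, not clearly beyond the scatter, perhaps a touch weaker. Compound 4 is estimated at 26000 nM, with a range from 8000 nM to 85000 nM.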

Compound 4, half-maximal inhibitory concentration: 80400 nM
Compound 4: middle estimate off by 3.1-fold (0.49 log units), on the low side; the range from low to high includes it.
By their numbers in this assay, from the lowest: compound 1; then compounds 3 and 2 (each within the scatter of the next); then compound 4.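

In this assay this position responds to the exchange: one heavy atom leaves and one enters, yet methyl in place of fluoro gives a 3.8-fold higher number from compound 2 to compound 4 (0.59 log units; beyond the scatter) and that step, though modest, lies beyond the scatter. So a single-group change on this aromatic carbon, two atoms from the ring nitrogen, is not silent, and of the two groups seen here, fluoro goes with the stronger inhibitor. Nothing available explains why the number rises.

Where a chlorine atom, an ethyl group or an amine at this position would fall remains open. Among these compounds, it also remains open whether the same exchange would give a similar step on a different core, since this single pair is the only evidence for it.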